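Piperazine for dimethylamino on the meta-substituted amide

A few compounds are considered here, and "the series" means these few. Any claim that something is new, unique, unknown or untested is made for them only; others in the source may bear on it.

Measured compounds:
compound 1 `CN(C)c1ccc(C(=O)Nc2n[nH]c3c2CN(Cc2cccc(F)c2F)C3(C)C)cc1` 69 nM
compound 2 `CN1CCN(c2ccc(C(=O)Nc3n[nH]c4c3CN(Cc3cccc(F)c3F)C4(C)C)cc2)CC1` 17 nM
compound 3 `CN(C)c1cccc(C(=O)Nc2n[nH]c3c2CN(Cc2cccc(F)c2F)C3(C)C)c1` 420 nM

These three share one core and differ only in the aromatic amide arm. In an assay on Sf21 cells for inhibition of high affinity nerve growth factor receptor (Homo sapiens), read by HTRF, with a stated time of 30 min, in the presence of a further agent that is not named here (a lower number here means a stronger inhibitor, a higher number a weaker inhibitor), compound 1 gives 69 nM. Compound 2 carries 4-methylpiperazin-1-yl in place of dimethylamino on an aromatic carbon and gives 17 nM; the step is a 4.1-fold lower number from compound 1 to compound 2 (0.61 log units; beyond the scatter). The change from compound 1 to compound 3 is 3-(dimethylamino)phenyl in place of 4-(dimethylamino)phenyl on a carbonyl carbon, the same atoms joined differently, and compound 3 gives 420 nM; the step is a 6.1-fold higher number from compound 1 to compound 3 (0.78 log units; beyond the scatter).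

Compound 4 `CN1CCN(c2cccc(C(=O)Nc3n[nH]c4c3CN(Cc3cccc(F)c3F)C4(C)C)c2)CC1` is not yet measured. It relates to compound 3 by 4-methylpiperazin-1-yl in place of dimethylamino on an aromatic carbon, the same kind of change as from compound 1 to compound 2, though here the place is meta rather than para to a large group. Resting on the step of a 4.1-fold lower number from compound 1 to compound 2 (0.61 log units; beyond the scatter), compound 4 is expected to give 130 nM in this assay, a step of a 3.2-fold lower number from compound 3 to compound 4 (0.51 log units; beyond the scatter), with the range 50 nM to 350 nM estimated.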

Compound 4, half-maximal inhibitory concentration: 210 nM
Beside the measured number, compound 4's estimate is 1.6-fold (0.21 log units) below it; measured number inside the range.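

In this assay, putting 4-methylpiperazin-1-yl in place of dimethylamino on the second core gives a 2.0-fold lower number from compound 3 to compound 4 (0.30 log units; within the scatter), a step that cannot be told apart from repeat-measurement noise. Set side by side, the steps on the two cores do not differ beyond what repeat measurements would allow: the same change on two cores in this assay, a 4.1-fold lower number (0.61 log units; beyond the scatter) from compound 1 to compound 2 and a 2.0-fold lower number (0.30 log units; within the scatter) from compound 3 to compound 4, 2.0-fold (0.31 log units) apart, within the scatter of two such steps So the change carries across without a detectable disagreement, but one pair per core does not show that its effect is truly equal on both, nor that it lowers the number on the second core at all.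

Going by these compounds, whether morpholine or piperidine in the same place would behave alike on both cores remains open. So does the effect of a carboxylic acid there.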